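Aryl urea cyanoaziridines: removing the acetyl group

The source may report more compounds than this note shows. Statements on the series, on what has been measured and on what is new or still open speak of the compounds shown alone.

Three cyanoaziridine ureas have been measured in a functional assay on MCF7 cells (Homo sapiens) for inhibition; on this read-out lower numbers stand for stronger inhibition and higher numbers for weaker inhibition. Compound 1 `CC(=O)c1cccc(NC(=O)N2CC2C#N)c1` gives 3500 nM, the lowest number of the three. Compound 2 `CCOC(=O)CNC(=O)N1CC1C#N` gives 11000 nM, and compound 3 `CNC(=O)N1CC1C#N` gives 18000 nM; both gaps to compound 1 lie beyond the scatter, so compound 1 is the most potent of this small set. Compound 4 `N#CC1CN1C(=O)Nc1ccccc1` differs from compound 1 in one place: hydrogen in place of acetyl on an aromatic carbon. For the measured compounds named here, no measured pair isolates this change, so its size is unknown from the data. A weakening is expected because compound 1 gives 3500 nM while the smaller ureas compound 2 and compound 3 stand higher. The step from compound 1 to compound 4 is estimated as a 2.3-fold higher number from compound 1 to compound 4 (0.36 log units; beyond the scatter), toward weaker inhibition. Compound 4 is therefore expected at 8000 nM, within 3000 nM to 22000 nM.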

Compound 4, half-maximal inhibitory concentration: 4300 nM
The estimate for compound 4 lay 1.9-fold (0.27 log units) above the measured number; measured number inside the range.
By their numbers in this assay, from the lowest: compounds 1 and 4 (each within the scatter of the next); then compounds 2 and 3 (each within the scatter of the next).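

Hydrogen in place of acetyl on this aromatic carbon gives a 1.2-fold higher number from compound 1 to compound 4 (0.09 log units; within the scatter), so in this assay the acetyl group is not needed to hold the level of inhibition seen with compound 1. At this place, the read-out tolerates the loss of all the group's heavy atoms without a change beyond the scatter. No available measurement bears on why this step is so small.

As far as these compounds go, whether an amine, a carboxylic acid or a longer chain at this place would shift the number remains open. So does the effect of acetyl on the other aromatic carbons.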